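Adding a Second Hydroxy Group to a Quinone Core

The source may hold more compounds than are shown below. What is called first, only, known or untested is meant among the compounds shown, and "the series" means these compounds.

Measured compounds:
- compound 1 `O=C1C=C(N2CCN(c3ccc(F)cc3)CC2)C(=O)c2ccccc21`: 11700 nM
- compound 2 `O=C1C(N2CCN(c3ccccc3)CC2)=CC(=O)c2c(O)cccc21`: 15200 nM
- compound 3 `O=C1C=C(N2CCN(c3ccc(F)cc3)CC2)C(=O)c2c(O)cccc21`: 8400 nM

All three were tested in a functional assay on DU-145 cells (Homo sapiens) for inhibition, read by MTT assay, with a stated time of 72 h; a higher number here means a weaker inhibitor, a lower number a stronger inhibitor. Compound 1 and compound 3 share a core and differ in one place: hydroxy in place of hydrogen on an aromatic carbon. The step of a 1.4-fold lower number from compound 1 to compound 3 (0.14 log units; within the scatter) is small and does not stand out from the scatter of repeated measurements. Compound 2 carries a different core, and the difference between the two cores is not broken down here. Its value and those of compound 1 and compound 3 lie within the scatter of one another, so no order among the three can be claimed.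

Compound 4 `O=C1C=C(N2CCN(c3ccccc3)CC2)C(=O)c2c(O)ccc(O)c21` has not yet been measured in this assay. It is obtained from compound 2 by hydroxy in place of hydrogen on an aromatic carbon. This is the same kind of change as from compound 1 to compound 3, though the surroundings differ: in compound 4 the entering hydroxy group sits para to a hydroxy group (1 heavy atom), a feature absent in compound 3. For the measured compounds named here, because the single measured example of this change, a 1.4-fold lower number from compound 1 to compound 3 (0.14 log units; within the scatter), stayed within the scatter, the expected step is likewise small: a 1.4-fold lower number from compound 2 to compound 4 (0.14 log units; within the scatter). Compound 4 is therefore estimated to give 11000 nM, with a likely range from 5000 nM to 25000 nM.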

Compound 4, half-maximal inhibitory concentration: 1300 nM
Compound 4: the middle estimate sits 8.5-fold (0.93 log units) above what was measured, outside the stated range (below it).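

In this assay the same change, hydroxy in place of hydrogen on an aromatic carbon, gave a large step on one core (a 12-fold lower number from compound 2 to compound 4 (1.07 log units; beyond the scatter)) but a small one on the other (a 1.4-fold lower number from compound 1 to compound 3 (0.14 log units; within the scatter)). The size of this step therefore did not carry over from one core to the other, and the two steps differ by more than measurement scatter: the same change on two cores in this assay, a 1.4-fold lower number (0.14 log units; within the scatter) from compound 1 to compound 3 and a 12-fold lower number (1.07 log units; beyond the scatter) from compound 2 to compound 4, 8.4-fold (0.92 log units) apart, beyond the scatter of two such steps. This does not show why they differ, since the entering hydroxy group in compound 4 sits para to a hydroxy group, a feature absent in compound 3, while compound 1 and compound 3 also carry a fluorine atom that compound 2 and compound 4 lack, and a single pair on each side cannot separate these differences.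

The compounds shown leave open whether the large step depends on the hydroxy group already present or would also appear with the fluorine atom in place. They also leave open whether a different group at the same aromatic carbon, such as an amine or a methoxy group, would give a similar step.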